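The source may hold more compounds than are shown below. What is called first, only, known or untested is meant among the compounds shown, and "the series" means these compounds.

Among the compounds with values here, in a functional assay on HT-29 cells (Homo sapiens) for inhibition, read by sulforhodamine B assay, with a stated time of 48 h (on this read-out lower numbers stand for stronger inhibition of growth and higher numbers for weaker inhibition of growth), compound 1 (`O=C(NNC(=O)c1ccc2[nH]c(-c3ccc([N+](=O)[O-])o3)nc2c1)c1ccccc1`) gives 31.3 ug/mL and stands level, within the scatter, with compound 2 (`COc1cc(C(=O)NNC(=O)c2ccc3[nH]c(-c4ccc([N+](=O)[O-])s4)nc3c2)cc(OC)c1OC`) at 62.5 ug/mL as the only other measured value. Within the data shown here, these two compounds differ in more than one place, so the series offers no measured step for the change at hand. Compound 3 (`COc1cccc(C(=O)NNC(=O)c2ccc3[nH]c(-c4ccc([N+](=O)[O-])o4)nc3c2)c1`) keeps the core of compound 1 and carries one change: methoxy in place of hydrogen on an aromatic carbon. Among the measured compounds shown here, with no precedent, no shift beyond the scatter is expected in this assay in either direction. The expected 1.1-fold higher number from compound 1 to compound 3 (0.05 log units; within the scatter) is small. Compound 3 is estimated at 35 ug/mL with an expected range from 12 ug/mL to 100 ug/mL in this read-out.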

Compound 3, concentration for 50% growth inhibition: 31.3 ug/mL
The estimate for compound 3 lay 1.1-fold (0.05 log units) above the measured number; the measured number falls inside the stated range.
By their numbers in this assay, from the lowest: compounds 1, 3 and 2 (each within the scatter of the next).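

In this assay, within the data shown here, methoxy in place of hydrogen on an aromatic carbon gives no change at the digits printed from compound 1 to compound 3 (within the scatter), the first step that can be read at a single place. Going from phenyl to 3-methoxyphenyl therefore leaves growth inhibition level, so this position takes a methoxy group without a shift beyond the scatter. No measured evidence accounts for this result. Going by these compounds, whether an amine or a carboxylic acid at the same position would also stay level remains open. So does whether the same step would read alike on the core of compound 2.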